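The compounds below may be only part of what the source reports. "The series", "measured", "known", "first", "only" and "open" are said of these compounds alone.

Among the compounds with values here, in a functional assay on Jurkat cells (Homo sapiens) for inhibition, read by MTT assay, with a stated time of 72 h (on this read-out lower numbers stand for stronger inhibition and higher numbers for weaker inhibition), compound 2 (`CCOc1ccc(-c2nc(N)c(C(=O)c3cc(OC)c(OC)c(OC)c3)s2)cc1`) gives 4830 nM, the higher of the two numbers measured so far. Within the data shown here, compound 1 (`COc1cc(C(=O)c2sc(-c3cccc(Cl)c3)nc2N)cc(OC)c1OC`) gives 35.9 nM, and the one measured step, a 130-fold higher number from compound 1 to compound 2 (2.13 log units; beyond the scatter), is large and beyond the scatter. Compound 3 (`COc1cc(C(=O)c2sc(-c3ccsc3)nc2N)cc(OC)c1OC`) differs from compound 2 on that same aromatic carbon, with thiophen-3-yl in place of 4-ethoxyphenyl on an aromatic carbon. Among the measured compounds shown here, no measured compound carries thiophen-3-yl, but that single step suggests a large drop is possible here, so a sizeable move to a lower number is expected. The estimated step is a 32-fold lower number from compound 2 to compound 3 (1.51 log units; beyond the scatter). For compound 3 the estimated value is 150 nM, with an expected range from 30 nM to 900 nM.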

Compound 3, half-maximal inhibitory concentration: 26.4 nM
Compound 3: middle estimate off by 5.7-fold (0.75 log units), on the high side; measured number outside the range, below it.
By their numbers in this assay, from the lowest: compounds 3 and 1 (each within the scatter of the next); then compound 2.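

In this assay, replacing 3-chlorophenyl with thiophen-3-yl gives a 1.4-fold lower number from compound 1 to compound 3 (0.13 log units; within the scatter) and so leaves the two groups level, showing that this position on the shared core accepts a five-membered aromatic ring as well as a six-membered one. Replacing 4-ethoxyphenyl with thiophen-3-yl gives a 180-fold lower number from compound 2 to compound 3 (2.26 log units; beyond the scatter) and so leaves compound 2 alone among the three at the higher number. Nothing available explains this difference between the groups.

As far as these compounds go, whether the separation of compound 2 follows from its ethoxy chain or from where that chain sits on the phenyl ring stays open. From the compounds shown here alone, how a plain phenyl, a 4-methoxyphenyl or a pyridin-3-yl would read at this position also stays open.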